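From a Nitro Group to a Ring Nitrogen

This account rests on a few compounds, and the source may have more. Where it says the series, first, only, none or still open, it means among the compounds named here.

Compound 2 `O=C(Nc1c(C(O)(C(F)(F)F)C(F)(F)F)ccc2ccccc12)c1cccc([N+](=O)[O-])c1` gives 427 nM in a functional assay (Sus scrofa) with sulfonylurea receptors; K-ATP channels (Homo sapiens) as the target (on this read-out lower numbers stand for an effect already at smaller amounts and higher numbers for an effect only at larger amounts of compound), the lower of the two numbers obtained so far. Compound 1 `O=C(Nc1c(C(O)(C(F)(F)F)C(F)(F)F)ccc2ccccc12)c1cccc(Cl)c1` gives 851 nM in this assay, and the step of a 2.0-fold lower number from compound 1 to compound 2 (0.30 log units; within the scatter) lies within the scatter, so the two compounds cannot be put in order on this read-out. Compound 3 `O=C(Nc1c(C(O)(C(F)(F)F)C(F)(F)F)ccc2ccccc12)c1cccnc1` differs from compound 2 by pyridin-3-yl in place of 3-nitrophenyl on a carbonyl carbon. For the measured compounds named here, no measured step bears directly on this exchange: the only step in hand, a 2.0-fold lower number from compound 1 to compound 2 (0.30 log units; within the scatter), concerns a different group and stayed within the scatter. Going by the values given here, with no precedent for replacing the whole ring, the expected step of a 1.6-fold higher number from compound 2 to compound 3 (0.21 log units; within the scatter) is worded as a mild rise in the number, not clearly beyond the scatter, with a wide range to allow for the unknown. For compound 3 the estimate in this assay is 700 nM, between 250 nM and 2000 nM.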

Compound 3, half-maximal effective concentration: 617 nM
Estimate against measurement, compound 3: 1.1-fold (0.05 log units) above; the range from low to high includes it.
By their numbers in this assay, from the lowest: compounds 2, 3 and 1 (each within the scatter of the next).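

The exchange of the whole 3-nitrophenyl group on the carbonyl carbon for pyridin-3-yl gives a 1.4-fold higher number from compound 2 to compound 3 (0.16 log units; within the scatter) in this assay, and the exchange of 3-chlorophenyl for the same ring gives a 1.4-fold lower number from compound 1 to compound 3 (0.14 log units; within the scatter). At this place, then, a six-membered aromatic ring with 1 hetero atom and no further substituent reads the same, within the scatter, as the two carbon-only rings that carry a nitro or a chloro group, so neither of those groups is needed to stay within this range. No data at hand offer an explanation for this result.

Still open, going by these compounds, is whether an aromatic ring is needed on this carbonyl carbon at all, which a piperidine or a simple methyl group could test. Also open, on these data alone, is how pyridin-4-yl, or an amine or a carboxylic acid on the ring, would read in this assay.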